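Oral bioavailability notes: methoxy in place of chloro

The source may report more compounds than this note shows. Statements on the series, on what has been measured and on what is new or still open speak of the compounds shown alone.

Measured so far:
compound 1, `CC(C)C[C@@]1(C(=O)O)C[C@H](C(N)=O)[C@H](c2nccs2)N1C(=O)c1ccc(C(C)(C)C)c(Cl)c1`, 5%
compound 2, `COc1cc(C(=O)N2[C@@H](c3nccs3)[C@H](CO)C[C@@]2(CC(C)C)C(=O)O)ccc1C(C)(C)C`, 11%

In an in vivo ADME assay on the whole organism (strain Sprague-Dawley) for pharmacokinetics, with Rattus norvegicus as the target (on this read-out lower numbers stand for lower oral bioavailability and higher numbers for higher oral bioavailability), compound 1 gives 5% and compound 2 gives 11%; the two values lie within the scatter of each other, so nothing separates them. Compound 3, `COc1cc(C(=O)N2[C@@H](c3nccs3)[C@@H](C(N)=O)C[C@@]2(CC(C)C)C(=O)O)ccc1C(C)(C)C`, is not yet measured. It differs from compound 1 by methoxy in place of chloro on an aromatic carbon. Compound 2 also carries a methoxy and sits close to compound 1 in this assay, which gives no sign of a move beyond the scatter. The step of a number 3 percentage points higher from compound 1 to compound 3 (within the scatter) is expected to stay within the scatter. Compound 3 is estimated at 8%, range 3% to 16%.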

Compound 3, oral bioavailability: 0.6%
For compound 3 the middle estimate is 7.4 percentage points above the measured one; the measured number lies below the stated range.
By their numbers in this assay, from the lowest: compounds 3, 1 and 2 (each within the scatter of the next, the first and the last beyond it).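

In this assay, methoxy in place of chloro on an aromatic carbon, ortho to a tert-butyl group, gives a number 4.4 percentage points lower from compound 1 to compound 3 (within the scatter). Going by these compounds alone, this is the first single-place reading of this change, as compounds 1 and 2 differ in more than one place, and it separates the two groups by no more than the scatter. No measurement in hand bears on this result. Going by these compounds, whether a fluoro, a nitrile or an amine on this aromatic carbon would read differently in this assay stays open. Also open, on these data alone, is whether the same change reads alike with another group in place of tert-butyl.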